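Piperidine amide replacing the pyrrolidinylethyl amide on the hexyl ester chain

A few compounds are considered here, and "the series" means these few. Any claim that something is new, unique, unknown or untested is made for them only; others in the source may bear on it.

Among the measured compounds shown here, compound 2 `O=C(CCC(=O)OCCCCCCSc1ccc([N+](=O)[O-])c2nonc12)NCCN1CCCC1` stands at the lower end of the two numbers measured so far: in an assay on isolated protein for inhibition of glutathione S-transferase P (Homo sapiens), with a stated time of 10 min (on this read-out lower numbers stand for stronger inhibition and higher numbers for weaker inhibition), compound 2 gives 460 nM. For the measured compounds named here, its only measured neighbour is compound 1 `Cc1ccccc1NC(=O)CCC(=O)OCCCCCCSc1ccc([N+](=O)[O-])c2nonc12`, which in this assay gives 4100 nM. Going by the values given here, the single measured step, an 8.9-fold lower number from compound 1 to compound 2 (0.95 log units; beyond the scatter), replaces the aryl amide substituent with the aminoalkyl one and is the only step that bears on the change now considered. Compound 3 `O=C(CCC(=O)N1CCCCC1)OCCCCCCSc1ccc([N+](=O)[O-])c2nonc12` differs from compound 2 by piperidin-1-yl in place of (2-(pyrrolidin-1-yl)ethyl)amino on a carbonyl carbon. This removes the group that the measured step had brought in, although it does not restore the aryl group of compound 1, so the step is judged from that one comparison alone. For compound 3 the expected step is a 5.4-fold higher number from compound 2 to compound 3 (0.74 log units; beyond the scatter), towards a higher number in this assay. Compound 3 is estimated at 2500 nM, with a range from 800 nM to 8000 nM.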

Compound 3, half-maximal inhibitory concentration: 500 nM
The estimate for compound 3 lay 5.0-fold (0.70 log units) above the measured number; measured number outside the range, below it.
By their numbers in this assay, from the lowest: compounds 2 and 3 (each within the scatter of the next); then compound 1.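

In this assay the change on this carbonyl carbon gives a 1.1-fold higher number from compound 2 to compound 3 (0.04 log units; within the scatter) and so shows that, for this pair, the amide hydrogen and the pyrrolidine ring of (2-(pyrrolidin-1-yl)ethyl)amino are not required for a number at the level of compound 2. The step of an 8.2-fold lower number from compound 1 to compound 3 (0.91 log units; beyond the scatter) points the same way as an 8.9-fold lower number from compound 1 to compound 2 (0.95 log units; beyond the scatter) and is also beyond the scatter, so the distance from compound 1 no longer rests on an aminoalkyl group alone, since piperidin-1-yl, with no hydrogen-bond donors, shows it too. No measurement here explains why these two groups read alike.

Going by these compounds, whether the higher number of compound 1 belongs to its 2-methylphenyl group or to aryl amides more widely stays open. Also open, on these data alone, is how a morpholine amide, a small dimethylamide or a free carboxylic acid on this carbonyl carbon would read.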